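A Pyrrolidinyl Group in Place of Phenyl on the Shared Core

The source may hold more compounds than are shown below. What is called first, only, known or untested is meant among the compounds shown, and "the series" means these compounds.

Compound 1 `COc1ccc(-c2noc(-c3ccccc3)n2)cc1OC1CCCC1`: in a functional assay on HCT-116 cells (Homo sapiens) for antiproliferative activity, read by MTT assay, with a stated time of 24 h (on this read-out higher numbers stand for weaker inhibition and lower numbers for stronger inhibition), compound 1 gives > 1000000 nM, which is a limit of the assay.
Compound 2 `COc1ccc(-c2noc(-c3ccc(F)cc3)n2)cc1O`: in this assay compound 2 gives > 1000000 nM, also a limit.
Compound 3 `COc1ccc(-c2noc(-c3ccc(F)cc3)n2)cc1OC1CCCC1`: in this assay compound 3 gives 210000 nM.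

Compound 1 stands at the limit of > 1000000 nM in this assay, at which 2 of the 3 values shown sit; among the three compounds only compound 3 has a number rather than a limit. The two measured steps are an at least 4.7-fold lower number from compound 1 to compound 3 (0.67 log units; beyond the scatter) and an at least 4.7-fold lower number from compound 2 to compound 3 (0.67 log units; beyond the scatter). Both concern substituents away from the phenyl and neither touches the position changed here.

Compound 4 `COc1ccc(-c2noc(C3CCCN3)n2)cc1OC1CCCC1` differs from compound 1 by pyrrolidin-2-yl in place of phenyl on an aromatic carbon. For the measured compounds named here, no measured step bears on this exchange, so the direction and size of any shift in this assay cannot be read from the data. Compound 1 sits at a limit, and compound 4 is expected to remain near that limit, with a step of a number no higher from compound 1 to compound 4 (the limit leaves the size open). The estimate for compound 4 is 1000000 nM, within a range from 300000 nM to 3000000 nM.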

Compound 4, half-maximal inhibitory concentration: 185000 nM
For compound 4 the middle estimate is 5.4-fold (0.73 log units) above the measured one; measured number outside the range, below it.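

Pyrrolidin-2-yl is the first group shown in place of phenyl at this position of the shared core, and in this assay the exchange gives an at least 5.4-fold lower number from compound 1 to compound 4 (0.73 log units; beyond the scatter). Set against the fluorinated phenyl, the same group gives a 1.1-fold lower number from compound 3 to compound 4 (0.06 log units; within the scatter), so a non-aromatic ring with a hydrogen-bond donor reads the same here as 4-fluorophenyl. The first step remains a bound rather than a size because of where compound 1 stands: the limit of > 1000000 nM in this assay, at which 2 of the 4 values shown sit.

The compounds shown do not separate the ring nitrogen from the ring that carries it, so how cyclohexyl or an open-chain amine would read at this position stays open. Also open, on these data alone, is whether pyrrolidin-2-yl would give the same reading with a hydrogen in place of the cyclopentyl on the oxygen.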